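Aryl ether imidazolines: thiophene in place of pyrazine

The compounds below may be only part of what the source reports. "The series", "measured", "known", "first", "only" and "open" are said of these compounds alone.

Measured so far in a functional assay for activation of Alpha-1D adrenergic receptor (Homo sapiens), read by calcium flux; a higher number here means that more compound is needed for the effect, a lower number that less compound is needed:
compound 1 `c1ccc(-c2cnccn2)c(OCC2=NCCN2)c1`: compound 1 gives < 100000 nM, a limit of the assay.
compound 2 `c1ccc(-c2ccns2)c(OCC2=NCCN2)c1`: compound 2 gives 25.1 nM.
compound 3 `c1ccc(-c2ncc[nH]2)c(OCC2=NCCN2)c1`: compound 3 gives < 100000 nM, a limit of the assay.

Compound 1 stands only at a limit in this assay, so no number is known for it. Compound 4 `Cc1ccc(-c2ccccc2OCC2=NCCN2)s1` differs from compound 1 by 5-methylthiophen-2-yl in place of pyrazin-2-yl on an aromatic carbon. Among the measured compounds shown here, the steps that bear on this are a step that the limit leaves unreadable from compound 1 to compound 2, a step that the two limits leave unreadable from compound 1 to compound 3 and a step that the limit leaves unreadable from compound 2 to compound 3; none has a readable size because of the limit of < 100000 nM in this assay, at which 2 of the 3 values shown sit. Only compound 2 gives a number, and compound 4 carries a five-membered sulfur-containing ring as compound 2 does. Compound 4 is therefore expected to land near compound 2, at 50 nM (range 10 nM to 400 nM), an expected step that the limit leaves unreadable from compound 1 to compound 4.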

Compound 4, half-maximal effective concentration: < 100000 nM
Compound 4 ended at the assay's limit; the forecaster's own chance of this, stated with the estimate: 10%; the middle value lies beyond the limit too.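

Compound 4 sits at a limit in this assay, as do compound 1 and compound 3, so no step from or to compound 4 can be read: the limit of < 100000 nM in this assay, at which 3 of the 4 values shown sit.

The compounds shown leave open what sets compound 2, with its 1,2-thiazol-5-yl group, apart from the other three.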